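The compounds below may be only part of what the source reports. "The series", "measured", "known", "first", "only" and "open" are said of these compounds alone.

Compound 1 `Cc1ccccc1N1CCCC(=O)N1` stands at the lower of the two numbers recorded in an assay on isolated protein for inhibition of Polyunsaturated fatty acid 5-lipoxygenase (Homo sapiens) (a higher number here means a weaker inhibitor, a lower number a stronger inhibitor), where compound 1 gives 57000 nM; compound 2 `CCc1ccc(N2CCCC(=O)N2)cc1` gives 125000 nM, a difference beyond the usual scatter. Compound 3 `O=C1CCCN(c2ccccc2Cl)N1` differs from compound 1 by chloro in place of methyl on an aromatic carbon. Among the compounds with values here, no measured pair shows this change, so the step from compound 1 to compound 3 is expected to remain within the scatter, with no clear direction, as a 1.1-fold lower number from compound 1 to compound 3 (0.06 log units; within the scatter). Compound 3 is therefore estimated at 50000 nM, with a likely range from 20000 nM to 130000 nM.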

Compound 3, half-maximal inhibitory concentration: 99000 nM
The estimate for compound 3 lay 2.0-fold (0.30 log units) below the measured number; the measured number falls inside the stated range.
By their numbers in this assay, from the lowest: compounds 1, 3 and 2 (each within the scatter of the next, the first and the last beyond it).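

In this assay, within the data shown here, the first measured pair at this position gives a 1.7-fold higher number from compound 1 to compound 3 (0.24 log units; within the scatter) for chloro in place of methyl on an aromatic carbon, ortho to a group of 7 heavy atoms. Either group is therefore accepted here, and the two compounds cannot be ranked against each other. Nothing available gives a reason for this step. From the compounds shown here alone, it remains open whether an amine, a methoxy group or a carboxylic acid on this carbon would stay within the scatter of compound 1. Going by these compounds, whether the same exchange would behave alike on another aromatic carbon also remains open.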